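From fluorophenyl to dimethylphenyl: an estimated step

The compounds below may be only part of what the source reports. "The series", "measured", "known", "first", "only" and "open" are said of these compounds alone.

Compound 2 `CCn1c(=O)/c(=C2\Sc3ccccc3N2C)s/c1=C\c1ccncc1Nc1ccccc1F` gives 360 nM in a functional assay on PC-3 cells (Homo sapiens) for inhibition; on this read-out lower numbers stand for stronger inhibition and higher numbers for weaker inhibition. Among the three measured compounds it stands second highest: compound 3 `CCn1c(=O)/c(=C2\Sc3cc(F)ccc3N2C)s/c1=C\c1ccncc1Nc1ccccc1F` gives 260 nM, and a 1.4-fold lower number from compound 2 to compound 3 (0.14 log units; within the scatter); compound 1 `c1ccc(Nc2cccc(-c3nc4ccccc4s3)c2)nc1`, built on a different core, gives 4800 nM. Compound 4 `CCn1c(=O)/c(=C2\Sc3ccccc3N2C)s/c1=C\c1ccncc1Nc1cc(C)ccc1C` differs from compound 2 by 2,5-dimethylphenyl in place of 2-fluorophenyl on a nitrogen on an aromatic ring. Among the measured compounds shown here, no measured step touches this ring: the only single-point step, a 1.4-fold lower number from compound 2 to compound 3 (0.14 log units; within the scatter), sits on another ring and stays within the scatter, and compound 2 and compound 3 carry the same (2-fluorophenyl)amino group. Compound 4 is therefore expected to show a 1.1-fold higher number from compound 2 to compound 4 (0.05 log units; within the scatter), no step beyond the scatter. Compound 4 is estimated at 400 nM, with a range from 150 nM to 1100 nM.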

Compound 4, half-maximal inhibitory concentration: 2000 nM
The estimate for compound 4 lay 5.0-fold (0.70 log units) below the measured number; the whole stated range lies below it.
By their numbers in this assay, from the lowest: compounds 3 and 2 (each within the scatter of the next); then compound 4; then compound 1.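

At this position, on a nitrogen on an aromatic ring, the group does matter in this assay: a 5.6-fold higher number from compound 2 to compound 4 (0.74 log units; beyond the scatter) lies beyond the scatter, whereas the earlier step on the other ring, a 1.4-fold lower number from compound 2 to compound 3 (0.14 log units; within the scatter), stays within it. Placing 2,5-dimethylphenyl here in place of 2-fluorophenyl weakens inhibition. Nothing available explains this step. Among the compounds shown here, the single change removes the fluoro group and adds both methyl groups, so the contribution of each remains open. Also open, going by these compounds, is how a phenyl ring carrying a carboxylic acid or a methoxy group would read here.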